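Nitroimidazo-oxazoles: cytotoxicity limits and a trifluoromethyl swap

The source may report more compounds than this note shows. Statements on the series, on what has been measured and on what is new or still open speak of the compounds shown alone.

Compound 1 `O=[N+]([O-])c1cn2c(n1)OC(COc1ccc(-c3ccc(F)cc3)nc1)C2` in an ADME assay on MRC5 cells (Homo sapiens) for cytotoxicity, read by fluorescence, with a stated time of 72 h (on this read-out lower numbers stand for stronger inhibition and higher numbers for weaker inhibition), gives > 64000 nM, which is a limit of the assay.
Compound 2 `O=[N+]([O-])c1cn2c(n1)OC(COc1ccc(-c3ccc(C(F)(F)F)cc3)nc1)C2` in this assay gives > 64000 nM, again a limit.
Compound 3 `CC1(COc2ccc(-c3ccc(F)cc3)cn2)Cn2cc([N+](=O)[O-])nc2O1` in this assay gives > 64000 nM, also a limit.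

Among the compounds with values here, all three measured values sit at the same limit (the limit of > 64000 nM in this assay, at which 3 of the 3 values shown sit), so no compound can be ranked against another here. From compound 1 to compound 2 the change is trifluoromethyl in place of fluoro on an aromatic carbon; the step it made, a step that the two limits leave unreadable from compound 1 to compound 2, cannot be read because both ends are limits. Compound 1 and compound 3 carry different cores, and the difference between the two cores is not broken down here.

Compound 4 `CC1(COc2ccc(-c3ccc(C(F)(F)F)cc3)cn2)Cn2cc([N+](=O)[O-])nc2O1` is not yet measured. It differs from compound 3 by trifluoromethyl in place of fluoro on an aromatic carbon, the same change already seen between compound 1 and compound 2. Since that earlier pair gave only limits, the step from compound 3 to compound 4 is expected to be a step that the limit leaves unreadable from compound 3 to compound 4, resting on compound 3 at > 64000 nM. Compound 4 is therefore estimated at 100000 nM in this assay, most likely reported once more as a limit.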

Compound 4, half-maximal inhibitory concentration: > 64000 nM
Compound 4: no number, only a limit (the forecaster's own chance of this, stated with the estimate: 85%); the middle value lies beyond the limit too.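

Going from compound 3 to compound 4, trifluoromethyl in place of fluoro gives no readable step, since both values are limits rather than numbers: the limit of > 64000 nM in this assay, at which 4 of the 4 values shown sit.

The compounds shown leave open how much cytotoxicity any of them has beyond that limit, and whether this swap changes it at all on either core.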